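This account rests on a few compounds, and the source may have more. Where it says the series, first, only, none or still open, it means among the compounds named here.

Among the compounds with values here, compound 1 `Nc1nc(NCc2ccccc2)c2ncn(/C=C3/CC3(CO)CO)c2n1` stands as the only compound with a number in an ADME assay on BCBL1 cells (Homo sapiens) for cytotoxicity, with a stated time of 7 days; a higher number here means that more compound is tolerated, a lower number that less compound is tolerated; in this assay compound 1 gives 19900 nM. Compound 2 `Nc1nc(N2CCCC2)c2ncn(/C=C3/CC3(CO)CO)c2n1` sits at a limit of this assay, > 20000 nM, not at a number. The step of a number no lower from compound 1 to compound 2 (the limit leaves the size open) has no readable size because one of its two values rests at the limit of > 20000 nM in this assay, at which 1 of the 2 values shown sits. Compound 3 `CCCCCOc1nc(N)nc2c1ncn2/C=C1/CC1(CO)CO` carries pentyloxy in place of benzylamino on an aromatic carbon. Within the data shown here, no measured step covers a pentyloxy group; the one step available points no lower. Compound 3 is expected to give 20000 nM, between 10000 nM and 40000 nM. The expected step of a 1.0-fold higher number from compound 1 to compound 3 (0.00 log units; within the scatter) is estimated as none beyond the scatter.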

Compound 3, half-maximal cytotoxic concentration: > 20000 nM
Compound 3: only a limit was reported; the forecaster's own chance of this, stated with the estimate: 50%; the middle value sits exactly at the limit.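

Replacing benzylamino with pentyloxy gives a number no lower from compound 1 to compound 3 (the limit leaves the size open), so a group with no ring and no hydrogen-bond donor also sits on this aromatic carbon without a lower number in this assay. Compound 3 gives > 20000 nM, which is a limit and not a number. The step between compound 2 and compound 3 cannot be read, and the series now gives little resolution at this position: the limit of > 20000 nM in this assay, at which 2 of the 3 values shown sit.

On these data alone, how a carboxylic acid or a longer chain on this carbon would read in this assay stays open. As far as these compounds go, whether any group here gives a number clearly lower than that of compound 1 also stays open.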